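The source may report more compounds than this note shows. Statements on the series, on what has been measured and on what is new or still open speak of the compounds shown alone.

Compound 1 `CC(=O)Oc1cc2c(CCC=C(C)C)c(C)ccc2cc1C(C)C`: 34400 nM
Compound 2 `CC(=O)Oc1cc2c(CC[C@@H]3OC(C)(C)OC3(C)C)c(C)ccc2cc1C(C)C`: 88900 nM
Compound 3 `CC(=O)Oc1cc2c(CC[C@H]3OC(C)(C)OC3(C)C)c(C)ccc2cc1C(C)C`: 36700 nM

These numbers come from a functional assay on SGC-7901 cells (Homo sapiens) for antiproliferative activity, read by sulforhodamine B assay, with a stated time of 72 h; a lower number here means a stronger inhibitor, a higher number a weaker inhibitor. Compound 3 sits level with compound 1, as a 1.1-fold higher number from compound 1 to compound 3 (0.03 log units; within the scatter) shows. Compound 2 stands apart from both, and a 2.4-fold lower number from compound 2 to compound 3 (0.38 log units; beyond the scatter) is the gap to compound 3. That gap comes with the fact that compounds 2 and 3 differ only in the configuration as drawn, so the drawn configuration alone separates those two values.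

The next compound is compound 4 `Cc1ccc2cc(C(C)C)c(O)cc2c1CC[C@H]1OC(C)(C)OC1(C)C`, which keeps everything in compound 3 except one group: hydrogen in place of acetyl on an oxygen on an aromatic ring. In words, hydrogen stands in place of acetyl on an oxygen on an aromatic ring, so acetoxy becomes hydroxy.

Among the compounds with values here, no measured pair makes this change. All three compounds carry the acetoxy group. The measured steps alter a different part of the molecule, and they offer only a rough sense of scale. Alongside the two steps above, a 2.6-fold higher number from compound 1 to compound 2 (0.41 log units; beyond the scatter) is the largest change from compound 1. Nothing measured gives a direction, so no step beyond the scatter is expected, though a modest one in either direction remains possible. The expected change is a 1.2-fold lower number from compound 3 to compound 4 (0.09 log units; within the scatter), and this is only an estimate. For compound 4 the estimated value in this assay is 30000 nM, with an expected range of 10000 nM to 85000 nM.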

Compound 4, half-maximal inhibitory concentration: 33100 nM
For compound 4 the middle estimate is 1.1-fold (0.04 log units) below the measured one, within the range that was stated.
By their numbers in this assay, from the lowest: compounds 4, 1 and 3 (each within the scatter of the next); then compound 2.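

Until now every compound carried the acetoxy group, so this position had shown no measured change at all. In this assay, within the data shown here, the first reading of it is a 1.1-fold lower number from compound 3 to compound 4 (0.04 log units; within the scatter), a step within the scatter: on this compound, hydrogen can stand in place of acetyl on the oxygen on the aromatic ring with no difference that the assay can separate from repeat-to-repeat variation, whereas the change of drawn configuration gave a 2.4-fold lower number from compound 2 to compound 3 (0.38 log units; beyond the scatter), a step beyond the scatter. Nothing at hand explains why the acetoxy and hydroxy forms give such similar numbers.

On these data alone, this reading comes from a single pair, so it remains open whether the same change would be as quiet on compound 2, with its opposite drawn configuration, or on compound 1, with its 2-methylprop-1-en-1-yl group. Also open, as far as these compounds go, is what other groups on this oxygen would do, such as a methyl group or a benzoyl group, or whether an amine in place of the hydroxy would give a different number.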